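The source may report more compounds than this note shows. Statements on the series, on what has been measured and on what is new or still open speak of the compounds shown alone.

Measured compounds:
compound 1 `CC1CCN(c2c(S(=O)(=O)c3ccc(F)c(Cl)c3)cnc3cc(Cl)ccc23)CC1` — 94%
compound 2 `CC1CCN(c2c(S(=O)(=O)c3ccc(C#N)cc3)cnc3cc(Cl)ccc23)CC1` — 70%
compound 3 `CC1CCN(c2c(S(=O)(=O)c3ccc(C#N)cc3)cnc3c(F)cccc23)CC1` — 86%

All values come from an assay on isolated protein for displacement of a labelled ligand from metabotropic glutamate receptor 5 (Homo sapiens), with a stated time of 60 min, tested at 1 uM; a lower number here means less inhibition, a higher number more inhibition at the concentration tested (going by the name of the read-out). In this assay compound 1 gives 94%, compound 2 gives 70% and compound 3 gives 86%. Compound 1 and compound 3 lie within the scatter of each other; compound 3 stands beyond the scatter from compound 2. Compound 1 and compound 2 share a core and differ in one place: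

3-chloro-4-fluorophenyl in place of 4-cyanophenyl on a sulfonyl sulfur

That change made the step of a number 24 percentage points higher from compound 2 to compound 1 (beyond the scatter). The cores of compound 2 and compound 3 differ, but the difference between the two cores is not broken down here.

Compound 4 `CC1CCN(c2c(S(=O)(=O)c3ccc(F)c(Cl)c3)cnc3c(F)cccc23)CC1` is not yet measured in this assay. It differs from compound 3 by:

3-chloro-4-fluorophenyl in place of 4-cyanophenyl on a sulfonyl sulfur

The place lines of both changes read the same, so this is the same change seen once already. For compound 4 a step of a number 9 percentage points higher from compound 3 to compound 4 (within the scatter) is expected, resting on the step of a number 24 percentage points higher from compound 2 to compound 1 (beyond the scatter) and on compound 3 already standing at 86%, which leaves little room upward. Compound 4 is therefore estimated at 95%, within a range of 87% to 100%.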

Compound 4, a percentage reported as inhibition, at one concentration (the size of the read-out at that concentration, not a potency): 95%
For compound 4 middle estimate and measured number coincide at the digits printed; low and high end bracket the measured number.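

In this assay the change to 3-chloro-4-fluorophenyl in place of 4-cyanophenyl on a sulfonyl sulfur gives a step of a number 9 percentage points higher from compound 3 to compound 4 (within the scatter) on the core of compound 3, so on this core the step does not stand clear of the scatter. With compound 3 at 86% and compound 4 at 95%, both close to the top of a percentage read-out taken at one concentration, the data do not show whether the two cores truly respond differently or the scale simply leaves less room, and one pair per core shows no general rule. What is shown is that the step cannot be carried from one core to the other at a fixed size:
the same change on two cores in this assay, a number 24 percentage points higher (beyond the scatter) from compound 2 to compound 1 and a number 9 percentage points higher (within the scatter) from compound 3 to compound 4, 15 percentage points apart, beyond the scatter of two such steps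

Among the compounds shown here, only two aryl groups on the sulfonyl sulfur appear here, so the outcome with an amine or a carboxylic acid on that phenyl ring, or a longer chain in its place, stays open. Potency also stays open, since a single-concentration percentage does not give it.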